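A few compounds are considered here, and "the series" means these few. Any claim that something is new, unique, unknown or untested is made for them only; others in the source may bear on it.

The measured compounds in a functional assay on A549 cells (Homo sapiens) for inhibition, with a stated time of 72 h; a higher number here means a weaker inhibitor, a lower number a stronger inhibitor:
compound 1, `O=C(Nc1ccccc1)Nc1nc(Sc2c[nH]c3ccccc23)cc(N2CCN(c3ccccn3)CC2)n1`, gives 30300 nM
compound 2, `Cc1cc(Cl)ccc1NC(=O)Nc1nc(Sc2c[nH]c3ccccc23)cc(N2CCCC2)n1`, gives 8930 nM

Among the measured compounds shown here, compound 2 holds the lower of the two numbers in this assay; its only neighbour is compound 1, whose number is higher by a margin beyond the usual scatter. Compound 3, `Cc1cc(Cl)ccc1NC(=O)Nc1nc(Sc2c[nH]c3ccccc23)cc(N2CCN(c3ccccn3)CC2)n1`, has not yet been measured. It differs from compound 2 in one place: 4-(pyridin-2-yl)piperazin-1-yl in place of pyrrolidin-1-yl on an aromatic carbon. For the measured compounds named here, the same 4-(pyridin-2-yl)piperazin-1-yl group is present in compound 1, which carries a different aryl urea and shows the higher number of the two, but no directly comparable step between measured compounds exists, so the direction rests on that single observation. The step of a 1.7-fold higher number from compound 2 to compound 3 (0.23 log units; within the scatter) in this assay is expected to be a modest move towards a weaker inhibitor, near the edge of the scatter. Compound 3 is therefore estimated at 15000 nM, with a range from 5000 nM to 45000 nM.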

Compound 3, half-maximal inhibitory concentration: > 50000 nM
Compound 3: no number, only a limit (the forecaster's own chance of this, stated with the estimate: 10%); middle value at least 3.3-fold (0.52 log units) away from the limit.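

Compound 3 gives no number in this assay, only a limit: the limit of > 50000 nM in this assay, at which 1 of the 3 values shown sits.

Among the compounds shown here, this supplies the first direct comparison at this position, on the aromatic carbon of the shared core: with the 4-chloro-2-methylphenyl urea held fixed, 4-(pyridin-2-yl)piperazin-1-yl in place of pyrrolidin-1-yl gives an at least 5.5-fold higher number from compound 2 to compound 3 (0.74 log units; beyond the scatter). With 4-(pyridin-2-yl)piperazin-1-yl held fixed, 4-chloro-2-methylphenyl in place of phenyl on an amide-type nitrogen gives an at least 1.6-fold higher number from compound 1 to compound 3 (0.21 log units; that floor lies within the scatter), so this step does not show a change beyond the scatter.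

The compounds shown leave open whether the loss follows from the piperazine ring or from the pyridine ring attached to it. A plain piperazin-1-yl or a morpholin-4-yl at this position would bear on that question, and its value could also show whether any six-membered ring here gives a weaker inhibitor than pyrrolidin-1-yl.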